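This account rests on a few compounds, and the source may have more. Where it says the series, first, only, none or still open, it means among the compounds named here.

In an ADME assay on microsomes from liver (Mus musculus) for metabolic stability, read by LC-MS, using NADPH, with a stated time of 10 min, tested at 0.1 uM (on this read-out lower numbers stand for slow clearance and higher numbers for fast clearance), two compounds on a shared core have measured numbers. Compound 1 (`O=C(NCCCCc1ccccc1)c1cccc(C2SCC(=O)N2c2ccccn2)c1`) gives 644 mL.min-1.g-1 and compound 2 (`O=C(NCCCCc1ccccc1)c1cccc(C2SCC(=O)N2c2cccc(F)c2)c1`) gives 2740 mL.min-1.g-1 as the higher of the two. Going by the values given here, the only measured step (a 4.3-fold higher number from compound 1 to compound 2 (0.63 log units; beyond the scatter)) is modest but lies beyond the scatter, and it puts 3-fluorophenyl in place of pyridin-2-yl on an amide-type nitrogen in a ring.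

Compound 3 (`O=C(NCCCCc1ccccc1)c1cccc(C2SCC(=O)N2c2ccc(C3CC3)cc2)c1`) changes that same place again (4-cyclopropylphenyl in place of 3-fluorophenyl on an amide-type nitrogen in a ring), with 4-cyclopropylphenyl in place of 3-fluorophenyl. Among the compounds with values here, both groups hold a six-membered aromatic ring of carbon only, and no measured compound carries the three-membered ring. The data therefore give no direct guide to this change, and no step beyond the scatter is expected in either direction in this assay on present evidence. The expectation rests on compound 2 at 2740 mL.min-1.g-1 and takes its width from the step at the same place (a 4.3-fold higher number from compound 1 to compound 2 (0.63 log units; beyond the scatter)). The expected step is a 1.1-fold higher number from compound 2 to compound 3 (0.04 log units; within the scatter) and it would stay within the scatter. For compound 3 the estimate is 3000 mL.min-1.g-1 (expected range 1300 mL.min-1.g-1 to 7000 mL.min-1.g-1).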

Compound 3, intrinsic clearance in microsomes: 2960 mL.min-1.g-1
Compound 3: the middle estimate sits 1.0-fold (0.01 log units) above what was measured, and the stated range covers the measured number.
By their numbers in this assay, from the lowest: compound 1; then compounds 2 and 3 (each within the scatter of the next).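

In this assay, the amide-type nitrogen in a ring now carries a second group built on a six-membered aromatic ring of carbon only, and the step is small (a 1.1-fold higher number from compound 2 to compound 3 (0.03 log units; within the scatter)). Losing the fluorine and gaining the three-membered ring therefore leaves the clearance number of compound 3 indistinguishable from that of compound 2 in this assay, even though the group entering is the larger by its count of heavy atoms. Compound 1, with pyridin-2-yl, now stands apart from both compounds with the all-carbon aromatic ring, since the new comparison (a 4.6-fold higher number from compound 1 to compound 3 (0.66 log units; beyond the scatter)) also lies beyond the scatter, though nothing at hand accounts for this separation.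

The compounds shown leave open whether pyridin-3-yl, or a phenyl ring bearing an amine or a carboxylic acid, would read nearer to compound 1 or nearer to compound 2 and compound 3. They also leave open whether a cyclopropyl group on a pyridine ring would keep the number of compound 1 or move it towards that of compound 3.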